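Methoxyethoxypyrimidine replaces methoxyphenyl on a thiazole core

The compounds below may be only part of what the source reports. "The series", "measured", "known", "first", "only" and "open" are said of these compounds alone.

Three compounds have been measured in a functional assay on U2OS cells for antagonist activity at C-X-C chemokine receptor type 3 (Homo sapiens), read by beta-arrestin recruitment; a higher number here means a weaker inhibitor, a lower number a stronger inhibitor:
compound 1, `CC[C@@H]1CN(c2scnc2-c2nc3ccccc3[nH]2)CCN1C(=O)Cn1cnc2cccnc21`, gives 604 nM;
compound 2, `C[C@@H]1CN(c2sc(CN(C)C)nc2-c2nc3ccccc3[nH]2)CCN1C(=O)Cn1cnc2cccnc21`, gives 2360 nM;
compound 3, `COc1ccc(-c2nc(C(F)(F)F)sc2N2CCN(C(=O)Cn3cnc4cccnc43)[C@H](C)C2)cc1`, gives 131 nM.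

Compound 3 holds the lowest of the three numbers, and its gap to each of the other two lies beyond the usual scatter, so it is the strongest inhibitor of the measured set. The unmeasured compound 4, `COCCOc1ncc(-c2nc(C(F)(F)F)sc2N2CCN(C(=O)Cn3cnc4cccnc43)[C@H](C)C2)cn1`, differs from compound 3 in one place: 2-(2-methoxyethoxy)pyrimidin-5-yl in place of 4-methoxyphenyl on an aromatic carbon. Among the compounds with values here, no step of this kind has been measured among the known compounds, so nothing shows how this exchange moves the readout. The estimate for compound 4 in this assay is therefore close to compound 3, a step of a 1.7-fold higher number from compound 3 to compound 4 (0.23 log units; within the scatter), with wide uncertainty; compound 4 is expected at 220 nM, between 70 nM and 700 nM.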

Compound 4, half-maximal inhibitory concentration: 324 nM
Compound 4: the middle estimate sits 1.5-fold (0.17 log units) below what was measured; the range from low to high includes it.
By their numbers in this assay, from the lowest: compound 3; then compounds 4 and 1 (each within the scatter of the next); then compound 2.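

In this assay, within the data shown here, this is the first reading of a change at the aromatic carbon next to the ring nitrogen: 2-(2-methoxyethoxy)pyrimidin-5-yl in place of 4-methoxyphenyl gives a 2.5-fold higher number from compound 3 to compound 4 (0.39 log units; beyond the scatter). The position therefore accepts this larger group, with its added ring nitrogens and chain, at a modest cost in inhibition. Nothing available accounts for the step.

The ring and the chain enter together, and the compounds shown do not separate their shares in the step. Also open, from the compounds shown here alone, is how a shorter 2-methoxypyrimidin-5-yl group or an amine on the pyrimidine would read here.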